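Amide aryl variation on the shared core

A few compounds are considered here, and "the series" means these few. Any claim that something is new, unique, unknown or untested is made for them only; others in the source may bear on it.

The series keeps one core and varies only the group on the amide carbonyl. In an assay on isolated protein for inhibition of aldehyde dehydrogenase 1A1 (Homo sapiens), read by spectrophotometry, tested at 10 uM (a lower number here means less inhibition, a higher number more inhibition at the concentration tested (going by the name of the read-out)), compound 3 `Cc1cccc(Cn2c(CN3CCN(C(=O)c4cccs4)CC3)nc3ccccc32)c1` gives 60.8%, the highest of the three numbers. Compound 1 `Cc1cccc(Cn2c(CN3CCN(C(=O)c4cccnc4)CC3)nc3ccccc32)c1` gives 24.5% and compound 2 `Cc1cccc(Cn2c(CN3CCN(C(=O)C4CCCCC4)CC3)nc3ccccc32)c1` gives 31.9%; these two are within the scatter of each other, a number 7.4 percentage points higher from compound 1 to compound 2 (within the scatter). Both steps onto compound 3 are clear: a number 36.3 percentage points higher from compound 1 to compound 3 (beyond the scatter) and a number 28.9 percentage points higher from compound 2 to compound 3 (beyond the scatter).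

Compound 4 `COc1ccc(C(=O)N2CCN(Cc3nc4ccccc4n3Cc3cccc(C)c3)CC2)cc1` is not yet measured. It differs from compound 3 as follows: 4-methoxyphenyl in place of thiophen-2-yl on a carbonyl carbon. Among the measured compounds shown here, no measured step covers this exact exchange. For the measured compounds named here, the steps that bear on it are the two leading into compound 3, which show the thiophen-2-yl group on the carbonyl carbon standing well above both the pyridin-3-yl and the cyclohexyl alternatives. The only other six-membered aromatic ring in the set is the pyridin-3-yl of compound 1, which gives 24.5%; compound 4 brings in a six-membered aromatic ring of carbon only, 4-methoxyphenyl. A downward step beyond the scatter is therefore expected, a number 25.8 percentage points lower from compound 3 to compound 4 (beyond the scatter). Compound 4 is estimated to give 35% in this assay, with a range from 15% to 55%.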

Compound 4, a percentage reported as inhibition, at one concentration (the size of the read-out at that concentration, not a potency): 55.5%
Compound 4: middle estimate off by 20.5 percentage points, on the low side; the whole stated range lies below it.
By their numbers in this assay, from the lowest: compounds 1 and 2 (each within the scatter of the next); then compounds 4 and 3 (each within the scatter of the next).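

In this assay the exchange of thiophen-2-yl for 4-methoxyphenyl on the carbonyl carbon is a small one, a number 5.3 percentage points lower from compound 3 to compound 4 (within the scatter), so a high number at this position is not confined to the thiophen-2-yl group: a six-membered aromatic ring of carbon only, with 8 heavy atoms against 5, reads level with the five-membered aromatic ring. The same group stands clear of the two lower compounds, a number 23.6 percentage points higher from compound 2 to compound 4 (beyond the scatter) and a number 31 percentage points higher from compound 1 to compound 4 (beyond the scatter), so the pyridin-3-yl of compound 1 can no longer stand for six-membered aromatic rings at this position, and compound 1 goes against any reading that an aromatic ring here is enough for a high number. Nothing available bears on what lies behind these differences.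

The compounds shown leave open how much of the number of compound 4 belongs to the methoxy group and how much to the ring, a question an unsubstituted phenyl group on the carbonyl carbon would address. They also leave open whether a furan-2-yl group would read with compound 3 or with compound 1.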